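Chlorination on Two Ring Positions and Liver Cell Toxicity

The compounds below may be only part of what the source reports. "The series", "measured", "known", "first", "only" and "open" are said of these compounds alone.

Measured compounds:
Compound 1, `Oc1ccccc1/C=N/c1sc2c(c1-c1nc3ccccc3s1)CCC2`: in an ADME assay on HepG2 cells (Homo sapiens) for cytotoxicity, read by MTT assay, with a stated time of 72 h (on this read-out higher numbers stand for lower toxicity in this test and lower numbers for higher toxicity in this test), compound 1 gives 156 ug/mL.
Compound 2, `Clc1ccc(/C=N/c2sc3c(c2-c2nc4ccccc4s2)CCCC3)cc1`: in this assay compound 2 gives 397 ug/mL.
Compound 3, `Clc1ccc(/C=N/c2sc3c(c2-c2nc4ccccc4s2)CCCC3)c(Cl)c1`: in this assay compound 3 gives 384 ug/mL.

Compound 1 has the lowest of the three numbers; compound 3 and compound 2 stand beyond the scatter above it. The difference between the core of compound 1 and the core of compound 2 is not broken down here.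

Compound 2 and compound 3 differ in one place, (chloro in place of hydrogen on an aromatic carbon). That change gave a 1.0-fold lower number from compound 2 to compound 3 (0.01 log units; within the scatter), so the two numbers stand within the scatter of each other and no order between them can be claimed.

Compound 4, `Oc1ccccc1/C=N/c1sc2c(c1-c1nc3cc(Cl)ccc3s1)CCC2`, is not yet measured in this assay. It differs from compound 1 by chloro in place of hydrogen on an aromatic carbon. This is the same kind of change as between compound 2 and compound 3, but not the same: in compound 3 the chloro sits ortho to a large group and meta to a chloro group on a phenyl ring, whereas in compound 4 it sits on a six-membered aromatic ring of carbon only that is part of a fused system of two rings, meta and para to a fused ring. Among the measured compounds shown here, because the one measured example of this kind of change gave a 1.0-fold lower number from compound 2 to compound 3 (0.01 log units; within the scatter), compound 4 is expected to give 150 ug/mL, a step of a 1.0-fold lower number from compound 1 to compound 4 (0.02 log units; within the scatter), with the range 70 ug/mL to 320 ug/mL allowing for the different place of the change and the scatter of this assay.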

Compound 4, half-maximal cytotoxic concentration: 210 ug/mL
The estimate for compound 4 lay 1.4-fold (0.15 log units) below the measured number, and the stated range covers the measured number.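

In this assay, chloro in place of hydrogen on an aromatic carbon gave a 1.3-fold higher number from compound 1 to compound 4 (0.13 log units; within the scatter), so compound 4 and compound 1 stand within the scatter of each other and no order between them can be claimed. Set beside the earlier example, the new step gives no sign that the outcome of this change depends on the core: the same change on two cores in this assay, a 1.0-fold lower number (0.01 log units; within the scatter) from compound 2 to compound 3 and a 1.3-fold higher number (0.13 log units; within the scatter) from compound 1 to compound 4, 1.4-fold (0.14 log units) apart, within the scatter of two such steps. This shows that, in these two pairs, the change carried from one core to the other without a step beyond the scatter, but it does not show that the same would hold on other cores or at other places, and the chloro enters at a different place in each pair, so two steps cannot separate the role of the core from the role of the place.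

The compounds shown leave open whether another group at the place taken by chloro in compound 4, such as a methoxy group, an amine or a carboxylic acid, would move the number beyond the scatter. They also leave open which of the differences between compound 1 and compound 2 accounts for the gap between their numbers, as the two differ in more than one place.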